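The compounds below may be only part of what the source reports. "The series", "measured", "known", "first", "only" and "open" are said of these compounds alone.

Measured in a functional assay on RS4-11 cells (Homo sapiens) for inhibition, read by CCK-8 assay, with a stated time of 48 h, tested at 20 uM; a lower number here means less inhibition of growth, a higher number more inhibition of growth at the concentration tested:
- compound 1 `N#C/C(=C\c1ccccc1OS(=O)(=O)c1ccccc1[N+](=O)[O-])C(=O)Nc1nnc(Cc2cccc3ccccc23)s1`: 66%
- compound 2 `Cc1ccc(S(=O)(=O)Oc2ccccc2/C=C(\C#N)C(=O)Nc2nnc(Cc3ccc(Cl)cc3)s2)cc1`: 69%

Compound 2 at 69% and compound 1 at 66% lie within the scatter of each other. Compound 3 `N#C/C(=C\c1ccccc1OS(=O)(=O)c1ccccc1[N+](=O)[O-])C(=O)Nc1nnc(Cc2ccc(Cl)cc2)s1` has 2-nitrophenyl in place of 4-methylphenyl on a sulfonyl sulfur. Among the compounds with values here, no measured pair differs in one place, so the series offers no direct precedent for this change. No step beyond the scatter is expected in this assay, in either direction. The expected change is a number 2 percentage points lower from compound 2 to compound 3 (within the scatter). For compound 3 the estimate is 67%, with an expected range of 52% to 82%.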

Compound 3, percent growth inhibition at one concentration: 65%
The estimate for compound 3 lay 2 percentage points above the measured number; the measured number falls inside the stated range.
By their numbers in this assay, from the lowest: compounds 3, 1 and 2 (each within the scatter of the next).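

In this assay, within the data shown here, the sulfonyl sulfur accepts 2-nitrophenyl in place of 4-methylphenyl, giving a number 4 percentage points lower from compound 2 to compound 3 (within the scatter) as the first single-place reading at this position. On the saturated chain carbon bound to an aromatic carbon, 4-chlorophenyl in place of naphthalen-1-yl gives a number 1 percentage points lower from compound 1 to compound 3 (within the scatter) and so also shows no step beyond the scatter. No evidence bears on the cause of either step.

On these data alone, whether a methyl or a pyridin-3-yl on the sulfonyl sulfur would keep this level of growth inhibition stays open. As far as these compounds go, each reading also comes from a single concentration, so the dose response remains open.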